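Phenyl in place of phenoxy: expected step

This account rests on a few compounds, and the source may have more. Where it says the series, first, only, none or still open, it means among the compounds named here.

In a functional assay on HCT-116 cells (Homo sapiens) for antiproliferative activity, read by WST assay, with a stated time of 72 h (a higher number here means a weaker inhibitor of growth, a lower number a stronger inhibitor of growth), compound 1 (`COc1ccc(CN[C@H]2[C@@H]3CN(c4ncc(C(=O)NO)cn4)C[C@@H]32)cc1`) gives 190 nM and compound 2 (`O=C(NO)c1cnc(N2C[C@@H]3[C@H](C2)[C@H]3NCc2ccc(Oc3ccccc3)cc2)nc1`) gives 120 nM. These two numbers lie within the scatter of each other, so compound 2 stands together with compound 1 and is not separated from it. Compound 3 (`O=C(NO)c1cnc(N2C[C@@H]3[C@H](C2)[C@H]3NCc2ccc(-c3ccccc3)cc2)nc1`) comes next: phenyl in place of phenoxy on an aromatic carbon, para to a large group. Within the data shown here, one measured step bears on this change: a 1.6-fold lower number from compound 1 to compound 2 (0.20 log units; within the scatter), with phenyl in place of methyl on an oxygen on an aromatic ring. That step created the phenoxy group that now leaves, and it stayed within the scatter. No step beyond the scatter is therefore expected in this assay. Compound 3 is estimated at 130 nM, with an expected range of 60 nM to 280 nM. The estimated change is a 1.1-fold higher number from compound 2 to compound 3 (0.03 log units; within the scatter).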

Compound 3, concentration for 50% growth inhibition: 56 nM
Estimate against measurement, compound 3: 2.3-fold (0.37 log units) above, outside the stated range (below it).
By their numbers in this assay, from the lowest: compound 3; then compounds 2 and 1 (each within the scatter of the next).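

In this assay, the aromatic carbon para to a large group proves sensitive to the group it carries: phenyl in place of phenoxy gives a 2.1-fold lower number from compound 2 to compound 3 (0.33 log units; beyond the scatter) and lies beyond the scatter, which the earlier change from methoxy to phenoxy at this carbon did not. Phenyl in place of methoxy gives a 3.4-fold lower number from compound 1 to compound 3 (0.53 log units; beyond the scatter) as well, so the directly attached phenyl separates from both oxygen-linked groups, while those two stand together within the scatter. No measurement at hand accounts for this difference.

As far as these compounds go, whether a benzyl group, an anilino group or a directly attached pyridine ring would stand with compound 3 remains open. Also open, from the compounds shown here alone, is what a fluorine or a carboxylic acid on the outer phenyl ring of compound 3 would do.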